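The source may report more compounds than this note shows. Statements on the series, on what has been measured and on what is new or still open speak of the compounds shown alone.

Series notes. Compound 1 `COc1ccc(C2=C(c3cc(OC)c(OC)c(OC)c3)C(=O)C(OC(C)=O)C2)cc1F` and compound 3 `COc1ccc(C2=C(c3cc(OC)c(OC)c(OC)c3)C(=O)C(OC(C)=O)C2)cc1Cl` share the core; in an ADME assay on MIA PaCa-2 cells (Homo sapiens) for cytotoxicity, read by MTT assay, with a stated time of 72 h (on this read-out lower numbers stand for stronger inhibition and higher numbers for weaker inhibition), compound 1 gives 39.5 ug/mL and compound 3 gives 24 ug/mL, so a 1.6-fold lower number from compound 1 to compound 3 (0.22 log units; within the scatter). Compound 2 `COc1ccc(C2=C(c3cc(OC)c(OC)c(OC)c3)C(=O)CC2O[SiH2]C(C)(C)C)cc1OC` is the third measured member. In this assay compound 2 gives only a limit, > 100 ug/mL, which is the limit of > 100 ug/mL in this assay, at which 1 of the 3 values shown sits. Compound 4 `COCOc1cc(C2=C(c3cc(OC)c(OC)c(OC)c3)C(=O)CC2O[SiH2]C(C)(C)C)ccc1OC` differs from compound 2 by methoxy in place of hydrogen on a saturated chain carbon bound to an oxygen on an aromatic ring. No measured step concerns a change of this kind; the single step shown, a 1.6-fold lower number from compound 1 to compound 3 (0.22 log units; within the scatter), belongs to a different pair and lies within the scatter. The expectation for compound 4 is therefore no step beyond the scatter, a step that the limit leaves unreadable from compound 2 to compound 4, and most probably again a limit rather than a number. Compound 4 is estimated at 120 ug/mL, range 40 ug/mL to 300 ug/mL, in this assay.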

Compound 4, half-maximal inhibitory concentration: 50 ug/mL
Estimate against measurement, compound 4: 2.4-fold (0.38 log units) above; the measured number falls inside the stated range.
By their numbers in this assay, from the lowest: compounds 3, 1 and 4 (each within the scatter of the next, the first and the last beyond it). At a limit, above all of these: compound 2.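

On the saturated chain carbon bound to an oxygen on an aromatic ring, methoxy in place of hydrogen gives a measured number in this assay where compound 2 gave none, with an at least 2.0-fold lower number from compound 2 to compound 4 (0.30 log units; that floor lies within the scatter). Within the data shown here, the earlier step changed only a halogen on an aromatic carbon, so this is the first reading at this position. Compound 2 stands at a limit, so the size of this step has only a floor: the limit of > 100 ug/mL in this assay, at which 1 of the 4 values shown sits.

As far as these compounds go, the true size of the step remains open. So does the outcome in this assay with a longer chain such as ethoxymethoxy, or with an amine, at this position.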